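Dimethylcarbamoyl in Place of Fluoro on the Fused Ring

A few compounds are considered here, and "the series" means these few. Any claim that something is new, unique, unknown or untested is made for them only; others in the source may bear on it.

Of the compounds shown here, two have been measured so far. In a functional assay on HEK293 cells for agonist activity at Free fatty acid receptor 1 (Homo sapiens), read by fluorescence and calcium flux, with a stated time of 10 min (a higher number here means a larger maximal response, a lower number a smaller maximal response), compound 2 `CC#C[C@@H](CC(=O)O)c1ccc(OC[C@H]2COc3ccc(F)cc3O2)cc1` gives 86%, the smaller of the two numbers shown, while compound 1 `CC#C[C@@H](CC(=O)O)c1ccc(OC[C@H]2COc3cccc(Cl)c3O2)cc1` gives 95%; the gap between them lies within the usual scatter. Compound 3 `CC#C[C@@H](CC(=O)O)c1ccc(OC[C@H]2COc3ccc(C(=O)N(C)C)cc3O2)cc1` has not been measured. Relative to compound 2 it carries one change: dimethylcarbamoyl in place of fluoro on an aromatic carbon. Going by the values given here, no measured pair shows a change of this kind, so its effect is unknown. Compound 3 is expected to keep a similar maximal response, with an expected step of a number 1 percentage points lower from compound 2 to compound 3 (within the scatter) not beyond the scatter. Compound 3 is estimated at 85%, between 65% and 100%.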

Compound 3, largest response reached (Emax), in percent of the reference or control that the assay uses: 32%
For compound 3 the middle estimate is 53 percentage points above the measured one; the measured number lies below the stated range.
By their numbers in this assay, from the lowest: compound 3; then compounds 2 and 1 (each within the scatter of the next).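

Swapping fluoro for dimethylcarbamoyl on this aromatic carbon gives a number 54 percentage points lower from compound 2 to compound 3 (beyond the scatter) in this assay and is the first change between compounds differing in one place. Going by these compounds alone, it shows that the maximal response depends strongly on what this carbon carries, which the earlier compounds could not show. Nothing available bears on the reason for the drop. On these data alone, it remains open whether a primary carboxamide, a nitrile or a methoxy group at this carbon would keep the response. Also open, as far as these compounds go, is how dimethylcarbamoyl would behave elsewhere on the same ring.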